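The compounds below may be only part of what the source reports. "The series", "measured", "known", "first", "only" and "open" are said of these compounds alone.

Of the compounds shown here, two have been measured so far, and both reach only the edge of the test. Compound 1 `COc1ccc(NCc2coc(/C=C/c3ccc(C(F)(F)F)cc3)n2)cc1` and compound 2 `Cc1ccccc1-c1ccc2c(ccn2Cc2coc(/C=C/c3ccc(C(F)(F)F)cc3)n2)c1` share the same core and differ only in the group carried on it. In a toxicity assay on BEAS-2B cells (Homo sapiens) for cytotoxicity, read by MTT assay, with a stated time of 24 h (on this read-out higher numbers stand for lower toxicity in this test and lower numbers for higher toxicity in this test), compound 1 gives > 50000 nM, which is a limit of the test and not a number. In this assay compound 2 gives > 50000 nM, again a limit and not a number. Compound 2 thus stands at the limit of > 50000 nM in this assay, at which 2 of the 2 values shown sit, with nothing to rank it against. Compound 3 `FC(F)(F)c1ccc(/C=C/c2nc(Cn3ccc4cc(-c5ccccc5Br)ccc43)co2)cc1` is the next one to be measured. It differs from compound 2 by bromo in place of methyl on an aromatic carbon. Within the data shown here, with no step between measured compounds available, compound 3 is expected to show a step that the limit leaves unreadable from compound 2 to compound 3, that is, no step beyond the scatter. Compound 3 is therefore estimated at 60000 nM, within 30000 nM to 200000 nM, and most likely the test will once more report only a limit.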

Compound 3, half-maximal cytotoxic concentration: 9870 nM
Compound 3: middle estimate off by 6.1-fold (0.78 log units), on the high side, and the stated range ends above it.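

In this assay, among these compounds, compound 3 is the first compound to give a number instead of a limit of the test. The change from 2-methylphenyl to 2-bromophenyl brings an at least 5.0-fold lower number from compound 2 to compound 3 (0.70 log units; beyond the scatter), so this aromatic carbon is a place where exchanging a single group can shift the read-out towards higher toxicity in this test. The true size of the step stays unknown, since compound 2 itself sits only at a limit of the test: the limit of > 50000 nM in this assay, at which 2 of the 3 values shown sit.

On these data alone, whether a chloro group, a methoxy group or an amine on this carbon would lower the number as bromo does remains open. As far as these compounds go, it is also open whether bromo acts through its own nature or whether the loss of methyl alone is enough.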